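The compounds below may be only part of what the source reports. "The series", "measured", "known", "first", "only" and "open" are said of these compounds alone.

Compound 1, `Cc1nc(N)c2nc(O)n(Cc3ccccc3)c2n1`: in a functional assay on the whole organism for activation, with Mus musculus as the target (a higher number here means that more compound is needed for the effect, a lower number that less compound is needed), compound 1 gives 3 mg/kg.
Compound 2, `Nc1nc(SCc2ccccc2)nc2c1nc(O)n2Cc1ccccc1`: in this assay compound 2 gives > 1 mg/kg, which is a limit of the measurement and not a number.

The step that the limit leaves unreadable from compound 1 to compound 2 cannot be read, since the limit of > 1 mg/kg in this assay, at which 1 of the 2 values shown sits, is all that is known of compound 2. On these data alone, compound 2 thus stands at a limit only; whether it sits close to compound 1 or far from it remains open.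

Compound 3, `CCCCCNc1nc(N)c2nc(O)n(Cc3ccccc3)c2n1`, differs from compound 2 in one place: pentylamino in place of benzylsulfanyl on an aromatic carbon. Among the compounds with values here, only one measured step touches this position, the one already described, and it is not readable, so no measured step supplies a size for the change to pentylamino. Within the data shown here, the expectation for compound 3 therefore leans on compound 1, whose value 3 mg/kg is the one readable number at this position. The step that the limit leaves unreadable from compound 2 to compound 3 is set as an expectation from an unreadable starting point. Compound 3 is expected to reach 3 mg/kg, within a range from 0.5 mg/kg to 30 mg/kg, with a fair chance that this assay again reports only a limit.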

Compound 3, minimum effective dose: 0.3 mg/kg
For compound 3 the middle estimate is 10-fold (1.00 log units) above the measured one, outside the stated range (below it).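

In this assay, within the data shown here, pentylamino in place of methyl on an aromatic carbon gives a 10-fold lower number from compound 1 to compound 3 (1.00 log units; beyond the scatter), which is the first readable step at this position between two ring nitrogen atoms and shows that the read-out responds to what is placed there. Pentylamino in place of benzylsulfanyl gives an at least 3.3-fold lower number from compound 2 to compound 3 (0.52 log units; beyond the scatter), so this change also lies beyond the usual scatter, although its true size may be larger than the printed bound. That bound rests on a limit for compound 2, which is not a number: the limit of > 1 mg/kg in this assay, at which 1 of the 3 values shown sits.

The step from methyl to benzylsulfanyl remains unreadable, and the compounds shown do not separate the contribution of the chain from that of the nitrogen attached to the ring, since pentylamino differs from methyl in both respects. On these data alone, whether a shorter chain such as propylamino, a longer chain such as heptylamino, or pentyloxy, with oxygen in place of that nitrogen, would give a number like that of compound 3 stays open, as does whether benzylamino would do so.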